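This account rests on a few compounds, and the source may have more. Where it says the series, first, only, none or still open, it means among the compounds named here.

The measured compounds in a functional assay on LoVo cells (Homo sapiens) for antiproliferative activity, read by sulforhodamine B assay, with a stated time of 48 h (on this read-out higher numbers stand for weaker inhibition and lower numbers for stronger inhibition), are:
compound 1, `NS(=O)(=O)c1ccc(N/C(S)=N\c2ccnc3cc(C(F)(F)F)ccc23)cc1`, 34500 nM
compound 2, `O=S(=O)(Nc1nccs1)c1ccc(N/C(S)=N\c2ccnc3cc(C(F)(F)F)ccc23)cc1`, 67100 nM
compound 3, `COc1cc(NS(=O)(=O)c2ccc(N/C(S)=N\c3ccnc4cc(C(F)(F)F)ccc34)cc2)nc(OC)n1`, 76700 nM

Compound 3 stands at the highest of the three numbers in this assay. Its separation from compound 2 is small: a 1.1-fold higher number from compound 2 to compound 3 (0.06 log units; within the scatter). From compound 1 the step is larger: a 2.2-fold higher number from compound 1 to compound 3 (0.35 log units; beyond the scatter). Compound 4, `COc1ncnc(NS(=O)(=O)c2ccc(N/C(S)=N\c3ccnc4cc(C(F)(F)F)ccc34)cc2)c1OC`, differs from compound 3 only in how the substituent on the sulfonamide nitrogen is put together: 5,6-dimethoxypyrimidin-4-yl in place of 2,6-dimethoxypyrimidin-4-yl on a sulfonamide nitrogen. Among the compounds with values here, all three measured compounds share the rest of the structure, so the steps that bear on this change are those at the same sulfonamide nitrogen. Replacing the hydrogen there by a ring group gave steps of this size: a 1.9-fold higher number from compound 1 to compound 2 (0.29 log units; within the scatter) and a 2.2-fold higher number from compound 1 to compound 3 (0.35 log units; beyond the scatter). Exchanging one ring group for another gave a 1.1-fold higher number from compound 2 to compound 3 (0.06 log units; within the scatter), a step within the scatter. The change from compound 3 to compound 4 is of the latter kind, the same atoms joined differently within one ring, so no step beyond the scatter is expected in this assay in either direction. The expected step is a 1.0-fold lower number from compound 3 to compound 4 (0.01 log units; within the scatter). Compound 4 is therefore expected to give 75000 nM, with a range from 35000 nM to 160000 nM.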

Compound 4, half-maximal inhibitory concentration: 28400 nM
For compound 4 the middle estimate is 2.6-fold (0.42 log units) above the measured one; the measured number lies below the stated range.
By their numbers in this assay, from the lowest: compounds 4, 1, 2 and 3 (each within the scatter of the next, the first and the last beyond it).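

In this assay, the arrangement of the same atoms within the ring on the sulfonamide nitrogen proved able to move the number: 5,6-dimethoxypyrimidin-4-yl in place of 2,6-dimethoxypyrimidin-4-yl gave a 2.7-fold lower number from compound 3 to compound 4 (0.43 log units; beyond the scatter), and 5,6-dimethoxypyrimidin-4-yl in place of 1,3-thiazol-2-yl gave a 2.4-fold lower number from compound 2 to compound 4 (0.37 log units; beyond the scatter), whereas the earlier exchange of one ring group for another had stayed within the scatter. Set against the unsubstituted sulfonamide, the new ring group gave a 1.2-fold lower number from compound 1 to compound 4 (0.08 log units; within the scatter), so, unlike 2,6-dimethoxypyrimidin-4-yl, 5,6-dimethoxypyrimidin-4-yl is not separated from hydrogen at this nitrogen. No measurement shown here accounts for the difference between the two dimethoxypyrimidinyl groups.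

The compounds shown leave open which of the two methoxy groups of compound 4 matters, since a pyrimidinyl group carrying a single methoxy group does not appear among them. They also leave open whether ethoxy groups in place of the methoxy groups, or a plain pyridinyl ring on the sulfonamide nitrogen, would stay level with compound 4 or return to the numbers of compound 2 and compound 3.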